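The source may hold more compounds than are shown below. What is called first, only, known or untested is meant among the compounds shown, and "the series" means these compounds.

Compound 1: `CN1CC[C@H](c2ccc(Cl)cc2)[C@@H](C(=O)OCCCCCc2ccccc2)C1` gives 382 nM in an assay on Cortex with Norepinephrine transporter (Rattus norvegicus) as the target; a lower number here means a stronger inhibitor, a higher number a weaker inhibitor.
Compound 2: `CCOC(=O)C[C@H]1CN(C)CC[C@@H]1c1ccc(Cl)cc1` gives 101 nM in this assay.

For the measured compounds named here, compound 2 holds the lower of the two numbers measured so far, and its gap to compound 1 lies beyond the usual scatter, so compound 2 is the stronger inhibitor of the pair. Compound 3, `COC(=O)/C=C/[C@H]1CN(C)CC[C@@H]1c1ccc(Cl)cc1`, is the next compound to be measured. It differs from compound 2 in one place: 2-(methoxycarbonyl)ethenyl in place of (ethoxycarbonyl)methyl on a saturated ring carbon. The shared core of compound 2 and compound 3 is otherwise kept. Going by the values given here, no measured pair shows this kind of exchange, so there is no step to lean on. The expected step from compound 2 to compound 3 is a 1.3-fold higher number from compound 2 to compound 3 (0.11 log units; within the scatter), a change not expected to go beyond the scatter. On that basis compound 3 is estimated at 130 nM, with a range from 40 nM to 420 nM.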

Compound 3, inhibition constant: 272 nM
Compound 3: middle estimate off by 2.1-fold (0.32 log units), on the low side; the range from low to high includes it.
By their numbers in this assay, from the lowest: compound 2; then compounds 3 and 1 (each within the scatter of the next).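

At this saturated ring carbon, two ring bonds from the ring nitrogen, placing 2-(methoxycarbonyl)ethenyl in place of (ethoxycarbonyl)methyl gives a 2.7-fold higher number from compound 2 to compound 3 (0.43 log units; beyond the scatter) in this assay. The number at this position therefore responds to the exchange even though both groups have the same counts of heavy atoms and hydrogen-bond acceptors; the entering group differs in carrying an additional double bond outside aromatic rings and a methyl rather than an ethyl ester. Nothing available explains this step.

The compounds shown leave open whether the step follows the double bond, the ester change or both together, which a saturated 2-(methoxycarbonyl)ethyl group could help separate. Going by these compounds, how a carboxylic acid or an amide at this carbon would read in this assay also remains open.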